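A few compounds are considered here, and "the series" means these few. Any claim that something is new, unique, unknown or untested is made for them only; others in the source may bear on it.

Working notes on the series. Compound 1, `CC1=C(/C=C/C(=O)/C=C/c2ccccc2)C(C)(C)CCC1`, in a functional assay on Hep cells (Homo sapiens) for cytotoxicity, read by sulforhodamine B assay, with a stated time of 48 h (a lower number here means a stronger inhibitor, a higher number a weaker inhibitor), gives 62200 nM. Compound 2, `CC1=C(/C=C/C(=O)/C=C/c2ccc(Cl)cc2)C(C)(C)CCC1`, carries a chloro on an aromatic carbon in place of hydrogen and in this assay gives 90600 nM; the step is a 1.5-fold higher number from compound 1 to compound 2 (0.16 log units; within the scatter). For the measured compounds named here, on the two numbers so far, compound 2 and compound 1 lie within the scatter of each other, so no order between them can be read.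

Compound 3, `CC1=C(/C=C/C(=O)/C=C/c2ccc(Br)cc2)C(C)(C)CCC1`, differs from compound 2 by bromo in place of chloro on an aromatic carbon. Going by the values given here, the only measured step that bears on a change at this position is a 1.5-fold higher number from compound 1 to compound 2 (0.16 log units; within the scatter), which did not move the number beyond the scatter; the exchange of one halogen for another at the same place is expected to behave the same way in this assay, with a step of a 1.1-fold lower number from compound 2 to compound 3 (0.03 log units; within the scatter) that is expected to stay within the scatter. Compound 3 is therefore estimated at 85000 nM, with a range from 40000 nM to 180000 nM.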

Compound 3, half-maximal inhibitory concentration: 34500 nM
Beside the measured number, compound 3's estimate is 2.5-fold (0.39 log units) above it; measured number below the stated range.
By their numbers in this assay, from the lowest: compounds 3, 1 and 2 (each within the scatter of the next, the first and the last beyond it).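

In this assay, for the compounds shown here, the position is not as flat as the earlier pair suggested: with the aromatic carbon para to a large group held constant, the exchange of one halogen for another gives a 2.6-fold lower number from compound 2 to compound 3 (0.42 log units; beyond the scatter) and is the first step to pass the scatter. Bromo in place of hydrogen gives a 1.8-fold lower number from compound 1 to compound 3 (0.26 log units; within the scatter) and stays within it, so compound 1 cannot be separated from either halogenated compound, and only the two halogens separate from each other. No measurement at hand accounts for the gap between chloro and bromo.

As far as these compounds go, whether the gap extends to fluoro or iodo at this position remains open. So does how an amine, a methoxy group or a carboxylic acid in the same place would read.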